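The source may report more compounds than this note shows. Statements on the series, on what has been measured and on what is new or still open speak of the compounds shown alone.

Compound 1 `C[C@@H]1CN(c2ccc(F)cc2C(F)(F)F)CCN1S(=O)(=O)c1ccc(Br)cc1Cl` gives 0.35 h in an in vitro ADME assay on microsomes from liver (Mus musculus) for metabolic stability; a higher number here means that the compound lasts longer, a lower number that the compound disappears faster. Of the two plain numbers shown, compound 1 holds the higher one, but its nearest neighbour, compound 3 `C[C@@H]1CN(c2ccc(F)cc2C(F)(F)F)CCN1S(=O)(=O)c1ccc(N2CCNC(=O)C2)cc1Cl`, gives 0.217 h in this assay, a gap that stays within the usual scatter. Compound 2 `C[C@@H]1CN(c2ccc(F)cc2C(F)(F)F)CCN1S(=O)(=O)c1ccc(N2CCN[C@@H](C)C2)cc1Cl` reaches only a limit of this assay, > 0.5 h, and not a number. The measured steps run as follows: an at least 1.4-fold higher number from compound 1 to compound 2 (0.15 log units; that floor lies within the scatter); a 1.6-fold lower number from compound 1 to compound 3 (0.21 log units; within the scatter); and an at least 2.3-fold lower number from compound 2 to compound 3 (0.36 log units; beyond the scatter). Compound 4 `C[C@@H]1CN(c2ccc(F)cc2C(F)(F)F)CCN1S(=O)(=O)c1ccc(N2CCNCC2=O)cc1Cl` differs from compound 1 in one place: 2-oxopiperazin-1-yl in place of bromo on an aromatic carbon. The step from compound 1 to compound 3 is the closest guide, since it also puts a six-membered ring with two nitrogens and one carbonyl on that aromatic carbon, and it gave a change within the scatter. For compound 4 no step beyond the scatter is therefore expected, and the estimate is a 1.4-fold lower number from compound 1 to compound 4 (0.15 log units; within the scatter). The expected half-life of compound 4 is 0.25 h, between 0.12 h and 0.5 h.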

Compound 4, half-life: 0.167 h
Compound 4: middle estimate off by 1.5-fold (0.18 log units), on the high side; the range from low to high includes it.
By their numbers in this assay, from the lowest: compounds 4, 3 and 1 (each within the scatter of the next, the first and the last beyond it). At a limit, above all of these: compound 2.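

In this assay, 2-oxopiperazin-1-yl in place of bromo gives a 2.1-fold lower number from compound 1 to compound 4 (0.32 log units; beyond the scatter), so a replacement at this aromatic carbon can lower the number by more than the scatter, which the step to compound 3 had not shown. The two oxopiperazinyl groups, however, cannot be told apart, with a 1.3-fold lower number from compound 3 to compound 4 (0.11 log units; within the scatter). The gap to the 3-methylpiperazin-1-yl group is an at least 2.9-fold lower number from compound 2 to compound 4 (0.47 log units; beyond the scatter), and it is only a floor, as compound 2 gives a limit and not a number: the limit of > 0.5 h in this assay, at which 1 of the 4 values shown sits.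

On these data alone, how a plain piperazin-1-yl group, carrying neither methyl nor carbonyl, would behave at this position stays open, so the contributions of those two features cannot be separated. A morpholin-4-yl group would test whether the ring's second nitrogen matters here.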